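Thiazole acetic acids: swapping the aryl group at the ring carbon

The source may hold more compounds than are shown below. What is called first, only, known or untested is meant among the compounds shown, and "the series" means these compounds.

Measured so far in an in vitro assay on HEK385-7 cells for displacement of a labelled ligand from prostaglandin D2 receptor 2 (Homo sapiens); on this read-out lower numbers stand for stronger inhibition and higher numbers for weaker inhibition:
- compound 1 `O=C(O)Cc1sc(C(c2ccc(F)cc2)c2ccc(F)cc2)nc1-c1ccc(Cl)cc1` gives 9.7 nM
- compound 2 `NS(=O)(=O)c1cccc(-c2nc(C(c3ccc(F)cc3)c3ccc(F)cc3)sc2CC(=O)O)c1` gives 140 nM
- compound 3 `O=C(O)Cc1sc(C(c2ccc(F)cc2)c2ccc(F)cc2)nc1-c1ccoc1` gives 14 nM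

On these numbers compound 3 sits second highest; its nearest neighbour is compound 1 a 1.4-fold higher number from compound 1 to compound 3 (0.16 log units; within the scatter), its furthest compound 2 a 10-fold lower number from compound 2 to compound 3 (1.00 log units; beyond the scatter).

Compound 4 `O=C(O)Cc1sc(C(c2ccc(F)cc2)c2ccc(F)cc2)nc1-c1ccnc(O)c1` differs from compound 3 by 2-hydroxypyridin-4-yl in place of furan-3-yl on an aromatic carbon. Within the data shown here, the one step that bears on it is the move to a group carrying a hydrogen-bond donor at the same carbon, a 14-fold higher number from compound 1 to compound 2 (1.16 log units; beyond the scatter), which went beyond the scatter. A step of the same direction, though smaller, is therefore expected in this assay for compound 4, a 5.0-fold higher number from compound 3 to compound 4 (0.70 log units; beyond the scatter), because a 14-fold higher number from compound 1 to compound 2 (1.16 log units; beyond the scatter). Compound 4 is estimated at 70 nM, within 25 nM to 250 nM.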

Compound 4, half-maximal inhibitory concentration: 68 nM
The estimate for compound 4 lay 1.0-fold (0.01 log units) above the measured number, and the stated range covers the measured number.
By their numbers in this assay, from the lowest: compounds 1 and 3 (each within the scatter of the next); then compound 4; then compound 2.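

In this assay, 2-hydroxypyridin-4-yl at this aromatic carbon is clearly less well tolerated than furan-3-yl, a 4.9-fold higher number from compound 3 to compound 4 (0.69 log units; beyond the scatter), and than 4-chlorophenyl, a 7.0-fold higher number from compound 1 to compound 4 (0.85 log units; beyond the scatter). It still does better than 3-sulfamoylphenyl, a 2.1-fold lower number from compound 2 to compound 4 (0.31 log units; beyond the scatter), so the penalty at this position varies with the group that enters. No supporting data bear on why these steps differ.

Whether the hydroxy group accounts for the loss remains open. A methoxy group or an amine in its place on the same six-membered ring would test this.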